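This account rests on a few compounds, and the source may have more. Where it says the series, first, only, none or still open, it means among the compounds named here.

Three carbamates sharing one core have been measured in an assay on isolated protein for inhibition of Fatty-acid amide hydrolase 1 (Homo sapiens), read by fluorescence, with a stated time of 30 min; a higher number here means a weaker inhibitor, a lower number a stronger inhibitor. Compound 1 `NC(=O)c1cc(-c2cccc(OC(=O)NC3CCCCC3)c2)n(-c2ccccc2)n1` gives 169 nM, compound 2 `CCN(CC)C(=O)c1cc(-c2cccc(OC(=O)NC3CCCCC3)c2)n(-c2ccccc2)n1` gives 448 nM, and compound 3 `CCOC(=O)c1cc(-c2ccc(OC(=O)NC3CCCCC3)cc2)nn1-c1ccc(Cl)cc1` gives 586 nM. Among these numbers compound 2 sits in the middle, with compound 3 within the scatter of it and compound 1 lying beyond. Going by the values given here, the single step joining two of them, a 2.7-fold higher number from compound 1 to compound 2 (0.42 log units; beyond the scatter), is modest. Compound 4 `CCCOC(=O)c1cc(-c2cccc(OC(=O)NC3CCCCC3)c2)n(-c2ccccc2)n1` differs from compound 2 by propoxy in place of diethylamino on a carbonyl carbon. Among the compounds with values here, no measured step bears directly on this change, and compound 3 differs from compound 4 in more than one place, so only its value can be noted. The expected step is a 1.1-fold higher number from compound 2 to compound 4 (0.05 log units; within the scatter), nothing beyond the scatter. Compound 4 is estimated at 500 nM, within a range from 200 nM to 1500 nM.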

Compound 4, half-maximal inhibitory concentration: 27 nM
Compound 4: middle estimate off by 19-fold (1.27 log units), on the high side, outside the stated range (below it).
By their numbers in this assay, from the lowest: compound 4; then compound 1; then compounds 2 and 3 (each within the scatter of the next).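

Going by these compounds alone, on this carbonyl carbon the choice of group matters more than the earlier compounds showed: the one earlier step was modest, whereas propoxy in place of diethylamino gives a large one (a 17-fold lower number from compound 2 to compound 4 (1.22 log units; beyond the scatter)). Propoxy also separates from amino, with a modest step beyond the scatter (a 6.3-fold lower number from compound 1 to compound 4 (0.80 log units; beyond the scatter)). No available evidence accounts for these differences. The compounds shown leave open whether a longer chain such as butoxy, or a carboxylic acid, on this carbonyl carbon would give a number as low as that of compound 4.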